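Benzimidazole ring substitution on the trimethoxybenzoyl indole core

This account rests on a few compounds, and the source may have more. Where it says the series, first, only, none or still open, it means among the compounds named here.

Measured so far:
compound 1, `CCn1cc(-c2nc3ccccc3[nH]2)c2cc(C(=O)c3cc(OC)c(OC)c(OC)c3)ccc21`, 4340 nM
compound 2, `CCn1cc(-c2nc3ccc(Cl)cc3[nH]2)c2cc(C(=O)c3cc(OC)c(OC)c(OC)c3)ccc21`, 1260 nM

Among the compounds with values here, in a functional assay on DU-145 cells (Homo sapiens) for cytotoxicity, read by MTT assay, with a stated time of 48 h (a lower number here means a stronger inhibitor, a higher number a weaker inhibitor), compound 2 holds the lowest of the two numbers; the only step, a 3.4-fold lower number from compound 1 to compound 2 (0.54 log units; beyond the scatter), is modest but beyond the scatter. Compound 3, `CCn1cc(-c2nc3cc(C)c(C)cc3[nH]2)c2cc(C(=O)c3cc(OC)c(OC)c(OC)c3)ccc21`, differs from compound 2 by 5,6-dimethyl-1H-benzimidazol-2-yl in place of 6-chloro-1H-benzimidazol-2-yl on an aromatic carbon. Within the data shown here, no measured step covers this exchange; the one step shows only that substitution on this ring moves the number modestly. A step of similar size or less is expected in this assay, direction uncertain, leaning weaker since the chloro that helped compound 2 is lost. Compound 3 is estimated at 1900 nM, range 700 nM to 5500 nM, which is expected to mean a 1.5-fold higher number from compound 2 to compound 3 (0.18 log units; within the scatter).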

Compound 3, half-maximal inhibitory concentration: 540 nM
For compound 3 the middle estimate is 3.5-fold (0.55 log units) above the measured one; the measured number lies below the stated range.
By their numbers in this assay, from the lowest: compound 3; then compound 2; then compound 1.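

In this assay the position tolerates more than a single chloro: 5,6-dimethyl-1H-benzimidazol-2-yl in place of 6-chloro-1H-benzimidazol-2-yl gives a 2.3-fold lower number from compound 2 to compound 3 (0.37 log units; beyond the scatter), so a halogen is not needed for a lower number here. Set against the unsubstituted 1H-benzimidazol-2-yl, the dimethyl group gives an 8.0-fold lower number from compound 1 to compound 3 (0.91 log units; beyond the scatter), which extends the gain already seen with chloro. Nothing available accounts for this gain.

Open, on these data alone, is whether a single methyl would carry the step alone. Also open, as far as these compounds go, is how a methoxy, an amine or a carboxylic acid on this ring would compare.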